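Chlorobenzyl position on the piperidine amides at the dopamine receptor

The source may hold more compounds than are shown below. What is called first, only, known or untested is meant among the compounds shown, and "the series" means these compounds.

Measured compounds and their numbers in an assay on isolated protein for displacement of a labelled ligand from D(4) dopamine receptor (Homo sapiens); on this read-out higher numbers stand for weaker inhibition and lower numbers for stronger inhibition:
compound 1, `O=C(NC1CCN(Cc2cccc(Cl)c2)CC1)c1cccc2ccccc12`: 116 nM
compound 2, `O=C(NC1CCN(Cc2ccc(Cl)cc2)CC1)c1cccc2ccccc12`: 43 nM
compound 3, `O=C(NC1CCN(Cc2cccc(Cl)c2)CC1)c1ccc2ccccc2c1`: 54 nM

Compound 3 stands on the numbers between the other two: its value sits within the scatter of that of compound 2, while compound 1 gives a number beyond the scatter from it. The unmeasured partner is compound 4, `O=C(NC1CCN(Cc2ccc(Cl)cc2)CC1)c1ccc2ccccc2c1`. The change from compound 3 to compound 4 is 4-chlorophenyl in place of 3-chlorophenyl on a saturated chain carbon bound to an amine nitrogen in a ring.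

Within the data shown here, one measured step bears directly on this change. In this assay it reads a 2.7-fold lower number from compound 1 to compound 2 (0.43 log units; beyond the scatter), the same exchange of the 3-chlorobenzyl for the 4-chlorobenzyl on the core of compound 1. Among the measured compounds shown here, whether that step carries over to the core of compound 3 is not known from these three compounds, since no other pair tests it. Taking it as the only guide, the step from compound 3 to compound 4 is expected to be of the same kind, a lower number beyond the scatter, and is estimated as a 2.7-fold lower number from compound 3 to compound 4 (0.43 log units; beyond the scatter). Compound 4 is therefore expected to give about 20 nM in this assay, in a range from 8 nM to 50 nM.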

Compound 4, inhibition constant: 37 nM
Compound 4: middle estimate off by 1.9-fold (0.27 log units), on the low side; the range from low to high includes it.
By their numbers in this assay, from the lowest: compounds 4, 2 and 3 (each within the scatter of the next); then compound 1.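

In this assay, the exchange of 3-chlorobenzyl for 4-chlorobenzyl on the core of compound 3 reads a 1.5-fold lower number from compound 3 to compound 4 (0.16 log units; within the scatter), so on this core the exchange gives no separation that stands clear of the scatter, unlike the step on the core of compound 1. Among these compounds, the two steps point the same way, yet only the one on the core of compound 1 lies beyond the scatter, and the gap between them does not show that the core alters the effect of the exchange: the same change on two cores in this assay, a 2.7-fold lower number (0.43 log units; beyond the scatter) from compound 1 to compound 2 and a 1.5-fold lower number (0.16 log units; within the scatter) from compound 3 to compound 4, 1.8-fold (0.27 log units) apart, within the scatter of two such steps. A single shared step size therefore remains compatible with both pairs, and a real dependence on the core is neither shown nor excluded.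

With two pairs and one exchange, the size of the step at this place stays poorly defined, and the true value could lie anywhere from negligible to modest. Also open, as far as these compounds go, is how an unsubstituted benzyl, a fluorobenzyl or a phenethyl chain on the piperidine nitrogen would read on these two cores, and whether any of them would separate the cores more clearly.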